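This account rests on a few compounds, and the source may have more. Where it says the series, first, only, none or still open, it means among the compounds named here.

Compound 1 `O=S(=O)(NCCNC(=S)Nc1cc(C(F)(F)F)cc(C(F)(F)F)c1)c1ccc(-c2ccccc2OCc2ccccc2)s1` is the starting point of this step. In a functional assay on RS4-11 cells (Homo sapiens) for inhibition, read by CCK-8 assay, with a stated time of 48 h (a higher number here means a weaker inhibitor, a lower number a stronger inhibitor), compound 1 gives > 50000 nM, which is a limit of the assay and not a measured number. Among the three values shown, compound 1 is the one at the limit of > 50000 nM in this assay, at which 1 of the 3 values shown sits. Two further compounds on the same core were measured: compound 2 `Cc1ccc(-c2ccsc2S(=O)(=O)NCCNC(=S)Nc2ccc([N+](=O)[O-])cc2)c(Oc2ccc(O)c(O)c2)c1` gives 5100 nM in this assay, and compound 3 `Cc1ccc(-c2ccsc2S(=O)(=O)NCCNC(=S)Nc2cc(C(F)(F)F)cc(C(F)(F)F)c2)c(Oc2ccc(O)c(O)c2)c1` gives 4800 nM; these two values lie within the usual scatter of each other, so no order between them can be read. Compound 4 `O=[N+]([O-])c1ccc(Oc2ccccc2-c2ccc(S(=O)(=O)NCCNC(=S)Nc3cc(C(F)(F)F)cc(C(F)(F)F)c3)s2)cc1` is the compound still to be measured. It differs from compound 1 in a single place: 4-nitrophenyl in place of benzyl on an oxygen on an aromatic ring. The benzyloxy group thus becomes a 4-nitrophenoxy group, closer in kind to the aromatic ethers of compound 2 at 5100 nM and compound 3 at 4800 nM, both of which gave real numbers. On that basis a gain is expected, and the step of an at least 2.5-fold lower number from compound 1 to compound 4 (0.39 log units; beyond the scatter) is estimated to be modest, with a fair chance that only a limit is reported again. For compound 4 the expected value in this assay is 20000 nM, within a range from 5000 nM to 60000 nM.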

Compound 4, half-maximal inhibitory concentration: 6300 nM
Beside the measured number, compound 4's estimate is 3.2-fold (0.50 log units) above it, within the range that was stated.
By their numbers in this assay, from the lowest: compounds 3, 2 and 4 (each within the scatter of the next). At a limit, above all of these: compound 1.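

Putting 4-nitrophenyl in place of benzyl on an oxygen on an aromatic ring gives an at least 7.9-fold lower number from compound 1 to compound 4 (0.89 log units; beyond the scatter) in this assay. This is the first step shown at this position, and it shows that the group carried on this oxygen can decide whether the compound gives a measurable number in this cell assay. Compound 1 stands at a limit and not at a measured number, which is why the true size of the step stays unknown and only its lower bound can be read: the limit of > 50000 nM in this assay, at which 1 of the 4 values shown sits.

The step swaps the whole group, so it cannot separate the effect of the nitro group from that of replacing benzyl with a ring attached directly to the oxygen; an unsubstituted phenyl on the same oxygen would separate them. As far as these compounds go, how an amine or a carboxylic acid in place of the nitro group would read also remains open.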